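Bis-benzylidene cyclohexanone series: chloro for hydrogen in compound 4

This account rests on a few compounds, and the source may have more. Where it says the series, first, only, none or still open, it means among the compounds named here.

Measured in a functional assay on CCRF-CEM cells (Homo sapiens) for cytotoxicity, with a stated time of 72 h; a higher number here means a weaker inhibitor, a lower number a stronger inhibitor:
compound 1 `Cc1ccc(/C=C2\CCC/C(=C\c3ccc([N+](=O)[O-])cc3)C2=O)cc1` gives 8530 nM
compound 2 `O=C1/C(=C/c2ccccc2)CCC/C1=C\c1ccc([N+](=O)[O-])cc1` gives 9320 nM
compound 3 `CN(C)c1ccc(/C=C2\CCC/C(=C\c3ccccc3[N+](=O)[O-])C2=O)cc1` gives 168000 nM

Compound 2 stands second highest of the three numbers; compound 1 sits nearest, within the scatter, and compound 3 furthest, beyond it. Among the measured compounds shown here, the one single-point step here, a 1.1-fold higher number from compound 1 to compound 2 (0.04 log units; within the scatter), shows that exchanging the substituent on that aromatic carbon did not move the number beyond the scatter.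

Compound 4 `O=C1/C(=C/c2ccc(Cl)cc2)CCC/C1=C\c1ccc([N+](=O)[O-])cc1` differs from compound 2 by chloro in place of hydrogen on an aromatic carbon. For the measured compounds named here, only the step from compound 1 to compound 2 bears on this change, and it was flat, so no step beyond the scatter is expected in this assay. Compound 4 is therefore estimated at 8000 nM, range 3500 nM to 18000 nM, an expected step of a 1.2-fold lower number from compound 2 to compound 4 (0.07 log units; within the scatter).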

Compound 4, half-maximal inhibitory concentration in the CCRF-CEM assay: 8180 nM
For compound 4 the middle estimate is 1.0-fold (0.01 log units) below the measured one; the range from low to high includes it.
By their numbers in the CCRF-CEM assay, from the lowest: compounds 4, 1 and 2 (each within the scatter of the next); then compound 3.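

On this aromatic carbon, para to a large group, the CCRF-CEM assay does not separate chloro from hydrogen or methyl: a 1.1-fold lower number from compound 2 to compound 4 (0.06 log units; within the scatter) and a 1.0-fold lower number from compound 1 to compound 4 (0.02 log units; within the scatter) join the earlier flat step. In a physicochemical assay for lipophilicity (on this read-out higher numbers stand for higher lipophilicity and lower numbers for lower lipophilicity), compound 2 gives 5.08 and compound 4 gives 5.08. No evidence at hand accounts for these flat steps.

As far as these compounds go, whether a carboxylic acid or a longer chain on this carbon would also leave the CCRF-CEM assay flat stays open. In the CCRF-CEM assay compound 3 gives 168000 nM, but it differs from the others in more than one place, so that value cannot be assigned to any single change.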